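Fluoro to cyclopentylcarbamoyl on the shared core

The source may report more compounds than this note shows. Statements on the series, on what has been measured and on what is new or still open speak of the compounds shown alone.

Measured so far in a functional assay on MCF7 cells (Homo sapiens) for antiproliferative activity, read by CCK-8 assay, with a stated time of 72 h; on this read-out higher numbers stand for weaker inhibition of growth and lower numbers for stronger inhibition of growth:
- compound 1 `CC[C@@H]1C(=O)N(C)c2cnc(-n3ccc4cc(F)ccc43)nc2N1C1CCCC1` gives "not active" (no number reported)
- compound 2 `CCCNC(=O)c1ccc2c(ccn2-c2ncc3c(n2)N(c2ccn(C)n2)C(CC)C(=O)N3C)c1` gives 6420 nM

In this assay compound 1 has no single number ("not active" (no number reported)) and so offers no numeric baseline. Compound 3 `CC[C@@H]1C(=O)N(C)c2cnc(-n3ccc4cc(C(=O)NC5CCCC5)ccc43)nc2N1C1CCCC1` remains unmeasured. Its structural difference from compound 1 (cyclopentylcarbamoyl in place of fluoro on an aromatic carbon) is cyclopentylcarbamoyl in place of fluoro on an aromatic carbon. Among the measured compounds shown here, no measured step between compounds differing in one place is available, so any step size is only an expectation. Compound 2, which also holds an amide, gives a number (6420 nM) and compound 1 does not. A move in this assay from no number to a measurable value, toward stronger inhibition of growth, is expected, although compound 3 may also give no number. For compound 3 the estimated value is 2500 nM (expected range 300 nM to 12000 nM).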

Compound 3, concentration for 50% growth inhibition: 795 nM
For compound 3 the middle estimate is 3.1-fold (0.50 log units) above the measured one; the range from low to high includes it.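

In this assay compound 1 gives "not active" (no number reported) and compound 3 gives 795 nM so no step can be read between the two. The compounds shown leave open how large a change cyclopentylcarbamoyl in place of fluoro brings where both partners carry a number. No measurement given here bears on the reason for this result.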